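From Hydroxy to Methylsulfonyl in a Metabolic Stability Series

The compounds below may be only part of what the source reports. "The series", "measured", "known", "first", "only" and "open" are said of these compounds alone.

In an ADME assay on microsomes from liver (Homo sapiens) for metabolic stability, read by LC-MS, with a stated time of 30 min, tested at 0.5 uM (on this read-out lower numbers stand for a less stable compound and higher numbers for a more stable compound), compound 1 (`c1ccc(-c2nc(-c3csc(N=C4NCCCN4)n3)cs2)cc1`) gives 83%. Compound 2 (`Oc1ccc(-c2nc(-c3csc(N=C4NCCCN4)n3)cs2)cc1`) gives 86%, which lies within the scatter of the number for compound 1, so the two compounds stand level on the readings so far. The next structure is compound 3 (`CS(=O)(=O)c1ccc(-c2nc(-c3csc(N=C4NCCCN4)n3)cs2)cc1`), which carries this change: methylsulfonyl in place of hydroxy on an aromatic carbon. In words, methylsulfonyl takes the place of hydroxy on an aromatic carbon, para to a large group.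

For the measured compounds named here, only one measured step bears on this change, and it concerns the same aromatic carbon: a number 3 percentage points higher from compound 1 to compound 2 (within the scatter). That step stays within the scatter, so exchanging hydrogen for hydroxy there left the read-out unmoved. Going by the values given here, no measured compound carries methylsulfonyl, so the data offer no direct evidence on that group, and the range must stay wide. On this single small step, no change beyond the scatter is expected, and the estimated step is a number 3 percentage points lower from compound 2 to compound 3 (within the scatter). In this assay, the expected value for compound 3 is 83%, with an estimated range of 68% to 94%.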

Compound 3, percent of the compound remaining: 87%
Compound 3: middle estimate off by 4 percentage points, on the low side; the measured number falls inside the stated range.
By their numbers in this assay, from the lowest: compounds 1, 2 and 3 (each within the scatter of the next).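

In this assay, the exchange of hydroxy for methylsulfonyl on this aromatic carbon, para to a large group, is a number 1 percentage points higher from compound 2 to compound 3 (within the scatter), and the full exchange of hydrogen for methylsulfonyl at the same place is a number 4 percentage points higher from compound 1 to compound 3 (within the scatter), so the three compounds stand level on this read-out. The earlier pair had shown this only for hydroxy, a group of 1 heavy atom with 1 hydrogen-bond donor, whereas compound 3 shows that the level reading also holds for methylsulfonyl, with 4 heavy atoms and 0 hydrogen-bond donors. No measurement in hand accounts for this insensitivity of the read-out to the group at this place, so the finding stands as an observation only.

The compounds shown leave open whether an amine, a carboxylic acid or a longer alkyl chain at this aromatic carbon would also stay within the scatter of these three numbers, or whether some such group would move the read-out clearly. They also leave open whether the same level reading would hold for a group at another carbon of this six-membered aromatic ring, or for a change elsewhere in the shared core.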